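The compounds below may be only part of what the source reports. "The series", "measured", "known", "first", "only" and "open" are said of these compounds alone.

Of the compounds shown here, two have so far been measured in an assay on HT-29 cells for inhibition of Serine-protein kinase ATM (Homo sapiens), read by fluorescence, with a stated time of 1 h; on this read-out higher numbers stand for weaker inhibition and lower numbers for stronger inhibition. Compound 1 `CCC(CC)CNc1c(C(N)=O)cnc2ccc(C#N)cc12` gives 820 nM in this assay, whereas compound 2 `C[C@@H](Nc1c(C(N)=O)cnc2ccc(C#N)cc12)c1ccc(Cl)cc1` gives 14400 nM. Compound 2 therefore stands at the higher of the two numbers, meaning it is the weaker inhibitor of the pair. The distance to compound 1 lies beyond the usual scatter of repeated measurements. The two compounds differ in more than one place, so the gap cannot be attributed to any single change.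

Compound 3 `C[C@@H](Nc1c(C(N)=O)cnc2ccc(-c3cccnc3)cc12)c1ccc(Cl)cc1` awaits measurement in this assay. It keeps the whole of compound 2 apart from one exchange: pyridin-3-yl in place of cyano on an aromatic carbon. Among the measured compounds shown here, no measured pair shows this particular exchange, so the expectation below rests on the numbers of compound 1 and compound 2 alone and on the nature of the change. A noticeable step toward a lower number, that is toward stronger inhibition, is expected, somewhat beyond the usual scatter, but the uncertainty is wide. Compound 3 is estimated at 3500 nM in this assay, within a range from 600 nM to 15000 nM. This estimate corresponds to an expected step of a 4.1-fold lower number from compound 2 to compound 3 (0.61 log units; beyond the scatter).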

Compound 3, half-maximal inhibitory concentration: 109 nM
Beside the measured number, compound 3's estimate is 32-fold (1.51 log units) above it; measured number outside the range, below it.
By their numbers in this assay, from the lowest: compound 3; then compound 1; then compound 2.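

In this assay the exchange of cyano for pyridin-3-yl brings a 130-fold lower number from compound 2 to compound 3 (2.12 log units; beyond the scatter), a large step well beyond the scatter. Among the compounds shown here, compound 1 and compound 2 differ in more than one place, so this is the first change here that can be read on its own: it shows that the group on this aromatic carbon of the fused two-ring system strongly affects the read-out, and that six heavy atoms with a ring can stand here in place of the two of cyano while inhibition becomes much stronger. The data in hand offer no measurement that explains why this single exchange has so large an effect.

Still open, as far as these compounds go, is whether the ring nitrogen of pyridin-3-yl matters, which a plain phenyl ring at this carbon would test, and whether a pyridin-4-yl ring or a small amine would do as well. Also open, from the compounds shown here alone, is whether the same exchange would give a similar step on the branched chain of compound 1 in place of the chlorophenyl-bearing group of compound 2.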